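A few compounds are considered here, and "the series" means these few. Any claim that something is new, unique, unknown or untested is made for them only; others in the source may bear on it.

Among the measured compounds shown here, in an ADME assay on HEK293 cells (Homo sapiens) for cytotoxicity, read by MTT assay, with a stated time of 48 h (on this read-out higher numbers stand for weaker inhibition and lower numbers for stronger inhibition), compound 1 `COc1cccc(-c2nc(SCC(=O)c3sc(-c4ccccc4)nc3C)[nH]c(=O)c2C#N)c1` gives 90200 nM and compound 2 `Cc1nc(-c2ccccc2)sc1C(=O)CSc1nc(-c2ccccc2)c(C#N)c(=O)[nH]1` gives 93500 nM, so compound 1 sits level with its only measured neighbour, within the scatter. Compound 3 `Cc1nc(-c2ccccc2)sc1C(=O)CSc1nc(-c2ccc(Cl)cc2)c(C#N)c(=O)[nH]1`, which carries a chloro on a different ring, gives "not determined" (no result reported), so it offers no numerical comparison.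

Compound 4 `COc1cccc(-c2nc(SCC(=O)c3sc(-c4ccc(Cl)cc4)nc3C)[nH]c(=O)c2C#N)c1` departs from compound 1 by chloro in place of hydrogen on an aromatic carbon, para to a large group. For the measured compounds named here, the only measured step is a 1.0-fold higher number from compound 1 to compound 2 (0.02 log units; within the scatter), hydrogen in place of methoxy on an aromatic carbon, and it lies within the scatter. That step involves a different group on a different ring, so it bears only indirectly on the new change. Going by the values given here, no measured pair tests a chloro group directly.

With so little evidence, no change beyond the scatter is expected in this assay. The expected step is a 1.2-fold lower number from compound 1 to compound 4 (0.08 log units; within the scatter). For compound 4, the estimated value is 75000 nM, with an expected range of 30000 nM to 160000 nM.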

Compound 4, half-maximal inhibitory concentration: 77900 nM
For compound 4 the middle estimate is 1.0-fold (0.02 log units) below the measured one, within the range that was stated.
By their numbers in this assay, from the lowest: compounds 4, 1 and 2 (each within the scatter of the next).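

Among the compounds shown here, the change from phenyl to 4-chlorophenyl gives a 1.2-fold lower number from compound 1 to compound 4 (0.06 log units; within the scatter) in this assay, the first direct reading at this position, para to a large group on a six-membered aromatic ring of carbon only. Chloro in place of hydrogen here leaves compound 4 level with compound 1, just as removing methoxy on the other aryl ring leaves the number level in a 1.0-fold higher number from compound 1 to compound 2 (0.02 log units; within the scatter), so neither single change has yet moved this cytotoxicity read-out beyond the scatter. No measurement on hand accounts for this result.

As far as these compounds go, whether an amine or a carboxylic acid in place of the chloro would shift the number beyond the scatter remains open. Also open, from the compounds shown here alone, is the effect of chloro on the other aryl ring, since compound 3 has no number to compare.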